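Removing the chloro group from a hydroxamic acid HDAC6 inhibitor

This account rests on a few compounds, and the source may have more. Where it says the series, first, only, none or still open, it means among the compounds named here.

Three compounds have been measured in an assay on isolated protein for inhibition of protein deacetylase HDAC6 (Homo sapiens), read by fluorescence, with stated times of 5 min and 60 min; on this read-out higher numbers stand for weaker inhibition and lower numbers for stronger inhibition:
compound 1 `O=C(CCC1C(=O)N(c2ccc(Cl)cc2)C(=O)N1Cc1ccc(Br)cc1)NCc1ccc(C(=O)NO)cc1` gives 16.5 nM;
compound 2 `Cc1ccc(CN2C(=O)N(c3ccc(Cl)cc3)C(=O)C2CCC(=O)NCc2ccc(C(=O)NO)cc2)cc1` gives 18.9 nM;
compound 3 `CN1C(=O)N(c2ccc(Cl)cc2)C(=O)C1CCC(=O)NCc1ccc(C(=O)NO)cc1` gives 11.8 nM.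

Compound 1 stands second highest of these three numbers. Its nearest neighbour is compound 2, with a 1.1-fold higher number from compound 1 to compound 2 (0.06 log units; within the scatter), and its furthest is compound 3, with a 1.4-fold lower number from compound 1 to compound 3 (0.15 log units; within the scatter). The remaining step, a 1.6-fold lower number from compound 2 to compound 3 (0.20 log units; within the scatter), is likewise within the scatter. All three steps concern the group on the other ring nitrogen of the shared core, not the chloro-bearing ring.

Compound 4 `O=C(CCC1C(=O)N(c2ccccc2)C(=O)N1Cc1ccc(Br)cc1)NCc1ccc(C(=O)NO)cc1` differs from compound 1 by hydrogen in place of chloro on an aromatic carbon. Among the measured compounds shown here, no measured step touches this ring, so nothing here bears directly on the change; the only guidance is that the core has so far tolerated changes elsewhere without a step beyond the scatter. A step of similar size, in no firm direction, is therefore expected, a 1.3-fold higher number from compound 1 to compound 4 (0.12 log units; within the scatter). Compound 4 is thus estimated at 22 nM, with a range from 8 nM to 60 nM.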

Compound 4, half-maximal inhibitory concentration: 13.6 nM
Estimate against measurement, compound 4: 1.6-fold (0.21 log units) above, and the stated range covers the measured number.
By their numbers in this assay, from the lowest: compounds 3, 4, 1 and 2 (each within the scatter of the next).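

Among the compounds shown here, this is the first measured change on the chloro-bearing ring: in this assay, replacing 4-chlorophenyl with phenyl gives a 1.2-fold lower number from compound 1 to compound 4 (0.08 log units; within the scatter) and so does not move the number beyond the scatter. The chloro group, para to a large group, can therefore be replaced by hydrogen with the rest of compound 1 unchanged, and this ring joins the group on the other ring nitrogen as a place where a single change has stayed within the scatter. For the compounds shown here, that finding covers only this one swap, and no supporting measurement is available to explain it.

From the compounds shown here alone, whether an amine, a carboxylic acid or a methoxy group in place of the chloro group would shift the number remains open. Going by these compounds, it is also open whether removing the chloro group gives a similarly small step when the other ring nitrogen carries the methyl group of compound 3 or the 4-methylbenzyl group of compound 2.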